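The source may hold more compounds than are shown below. What is called first, only, known or untested is meant among the compounds shown, and "the series" means these compounds.

Measured in a functional assay on HepG2 cells (Homo sapiens) for cytotoxicity, read by sulforhodamine B assay, with a stated time of 48 h; a higher number here means a weaker inhibitor, a lower number a stronger inhibitor:

- compound 1 `COc1ccc(/C=C/C(=O)c2cccc(-c3ccc(F)cc3)c2)cc1`: 5650 nM
- compound 2 `COc1cc(/C=C/C(=O)c2ccc(N)c(-c3ccc(F)cc3)c2)ccc1O`: 4300 nM

For the measured compounds named here, only these two compounds have numbers in this assay so far. Compound 2, at 4300 nM, stands within the usual scatter of compound 1, at 5650 nM, so the two cannot be told apart on this read-out.

The next compound is compound 3 `COc1ccc(/C=C/C(=O)c2ccc(N)c(-c3ccc(F)cc3)c2)cc1`. It is compound 2 with 4-methoxyphenyl in place of 4-hydroxy-3-methoxyphenyl on a double-bonded chain carbon bound to a double-bonded chain carbon. The rest of compound 2 stays as it is.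

Going by the values given here, no measured pair in this small set isolates this exchange, so the data give no direct guide to its effect. With compound 2 at 4300 nM as the starting point, no shift beyond the scatter is expected in this assay, and no direction is favoured. The expected size of the change is a 1.2-fold higher number from compound 2 to compound 3 (0.07 log units; within the scatter), which is an estimate only. The estimated value for compound 3 is 5000 nM, with an expected range from 2300 nM to 11000 nM.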

Compound 3, half-maximal inhibitory concentration: 3750 nM
Compound 3: the middle estimate sits 1.3-fold (0.12 log units) above what was measured, and the stated range covers the measured number.
By their numbers in this assay, from the lowest: compounds 3, 2 and 1 (each within the scatter of the next).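

In this assay, the exchange of 4-hydroxy-3-methoxyphenyl for 4-methoxyphenyl on a double-bonded chain carbon bound to a double-bonded chain carbon gives a 1.1-fold lower number from compound 2 to compound 3 (0.06 log units; within the scatter) and so stays within the scatter, which shows that this position tolerates this particular exchange on this read-out, even with one hydrogen-bond donor and one hydrogen-bond acceptor fewer in the entering group. For the compounds shown here, compound 3 also gives the first comparison that isolates amino in place of hydrogen on an aromatic carbon, with a 1.5-fold lower number from compound 1 to compound 3 (0.18 log units; within the scatter) also printed as within the scatter, so this single exchange cannot be told apart from no effect in these data. Nothing available bears on why either exchange leaves the read-out within the scatter.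

What the compounds shown leave open is whether any group at the first position can move the number beyond the scatter, for instance a 4-dimethylaminophenyl or a 4-carboxyphenyl in place of 4-methoxyphenyl. As far as these compounds go, it also remains open whether an acetamide or a methylamino group in place of amino on that aromatic carbon would separate from compound 3 in this assay at all.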